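Adding a Benzyloxy Group to a Sulfonamide Pyrazoline

A few compounds are considered here, and "the series" means these few. Any claim that something is new, unique, unknown or untested is made for them only; others in the source may bear on it.

Measured compounds:
Compound 1, `NS(=O)(=O)c1ccc(N2N=C(c3ccc(OCc4ccccc4)cc3)CC2c2ccccc2F)cc1`: 90000 nM
Compound 2, `NS(=O)(=O)c1ccc(N2N=C(c3ccc(OCc4ccccc4)cc3)CC2c2ccc(Cl)cc2)cc1`: 15000 nM
Compound 3, `NS(=O)(=O)c1ccc(N2N=C(c3ccccc3)CC2c2ccccc2Cl)cc1`: 13000 nM

In an ADME assay on BHK-21 cells (Mesocricetus auratus) for cytotoxicity, read by MTT assay, with a stated time of 72 h (a higher number here means that more compound is tolerated, a lower number that less compound is tolerated), compound 3 gives the lowest of the three numbers. For the measured compounds named here, its value and that of compound 2 lie within the scatter of each other, while the number for compound 1 stands well beyond it, about as far as the single measured step, a 6.0-fold lower number from compound 1 to compound 2 (0.78 log units; beyond the scatter), which changes the phenyl ring on the saturated carbon and so concerns a different position.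

Compound 4, `NS(=O)(=O)c1ccc(N2N=C(c3ccc(OCc4ccccc4)cc3)CC2c2ccccc2Cl)cc1`, differs from compound 3 by benzyloxy in place of hydrogen on an aromatic carbon. Going by the values given here, no measured pair isolates this change. The two compounds that carry the benzyloxy group, compound 1 and compound 2, give numbers on both sides of compound 3, so the group alone gives no clear direction. Compound 4 is therefore expected to stay close to compound 3, with a step of a 1.2-fold higher number from compound 3 to compound 4 (0.06 log units; within the scatter) that is not expected to exceed the scatter. The estimated value for compound 4 in this assay is 15000 nM, within 5000 nM to 45000 nM.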

Compound 4, half-maximal cytotoxic concentration: 12000 nM
Compound 4: the middle estimate sits 1.3-fold (0.10 log units) above what was measured; the range from low to high includes it.
By their numbers in this assay, from the lowest: compounds 4, 3 and 2 (each within the scatter of the next); then compound 1.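

In this assay, for the compounds shown here, the first pair to isolate benzyloxy in place of hydrogen on an aromatic carbon gives a 1.1-fold lower number from compound 3 to compound 4 (0.03 log units; within the scatter) and so shows that this group, para to a large group, brings no difference that can be told from the scatter when 2-chlorophenyl sits on the saturated ring carbon. With benzyloxy present, 2-chlorophenyl in place of 4-chlorophenyl on that carbon gives a 1.3-fold lower number from compound 2 to compound 4 (0.10 log units; within the scatter) and likewise stays within the scatter, whereas chloro in place of fluoro on an aromatic carbon gives a 7.5-fold lower number from compound 1 to compound 4 (0.88 log units; beyond the scatter) and so places the larger step at the halogen and not at the benzyloxy position. Nothing available explains these steps.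

Going by these compounds, whether an amine, a carboxylic acid or a longer chain at this aromatic carbon would stay as close to compound 3 remains open. On these data alone, it is also open whether benzyloxy would give so small a step alongside the 2-fluorophenyl group of compound 1.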